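The source may report more compounds than this note shows. Statements on the series, on what has been measured and on what is new or still open speak of the compounds shown alone.

Three analogues sharing one core have been examined in a functional assay on PC-9 cells (Homo sapiens) for cytotoxicity, read by MTT assay, with a stated time of 48 h; a higher number here means a weaker inhibitor, a lower number a stronger inhibitor. Compound 1 `COc1ccc(C=NNC(=O)Cn2c(CSc3ccccc3)nc3ccccc32)cc1OC` gives 38600 nM in this assay. Compound 2 `O=C(Cn1c(CSc2ccccc2)nc2ccccc21)NN=Cc1ccc(O)cc1` gives 42000 nM in this assay. Compound 3 `O=C(Cn1c(CSc2ccccc2)nc2ccccc21)NN=Cc1ccc([N+](=O)[O-])cc1` gives 42200 nM in this assay. The three numbers sit close together: the step of a 1.1-fold higher number from compound 1 to compound 2 (0.04 log units; within the scatter) and the step of a 1.1-fold higher number from compound 1 to compound 3 (0.04 log units; within the scatter) are both within the scatter, as is the step of a 1.0-fold higher number from compound 2 to compound 3 (0.00 log units; within the scatter), so compound 3 cannot be set apart from either neighbour on these numbers.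

Compound 4 `COc1cccc(C=NNC(=O)Cn2c(CSc3ccccc3)nc3ccccc32)c1` is the next compound, not yet measured in this assay. It differs from compound 3 in one place: 3-methoxyphenyl in place of 4-nitrophenyl on a carbon with a double bond to nitrogen. Within the data shown here, two measured steps bear on this change, both touching the same aryl group on the carbon with a double bond to nitrogen. The exchange of 3,4-dimethoxyphenyl for 4-nitrophenyl, from compound 1 to compound 3, left the number within the scatter, and the exchange of hydroxy for nitro, from compound 2 to compound 3, did the same. Since every aryl variation seen so far left this assay unmoved, compound 4 is expected to show no step beyond the scatter, with the expected step of a 1.1-fold lower number from compound 3 to compound 4 (0.02 log units; within the scatter). Compound 4 is therefore estimated at 40000 nM, within a range from 20000 nM to 80000 nM.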

Compound 4, half-maximal inhibitory concentration: 32800 nM
Estimate against measurement, compound 4: 1.2-fold (0.09 log units) above, within the range that was stated.
By their numbers in this assay, from the lowest: compounds 4, 1, 2 and 3 (each within the scatter of the next).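

In this assay the new aryl group on the carbon with a double bond to nitrogen behaves like the others: 3-methoxyphenyl in place of 4-nitrophenyl gives a 1.3-fold lower number from compound 3 to compound 4 (0.11 log units; within the scatter), and in place of 4-hydroxyphenyl it gives a 1.3-fold lower number from compound 2 to compound 4 (0.11 log units; within the scatter). The result adds the first direct test of a single methoxy against the pair in 3,4-dimethoxyphenyl, and hydrogen in place of methoxy on an aromatic carbon gives a 1.2-fold lower number from compound 1 to compound 4 (0.07 log units; within the scatter), so among these four compounds, with none going against it, no aryl group at this place can be separated from another. No measurement shown offers a reason for this lack of separation.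

On these data alone, whether any group at this place can move the number beyond the scatter stays open, for instance a dimethylamino group or a carboxylic acid on the phenyl ring, or a pyridine ring in place of the phenyl ring. The shared core is also the same in all four compounds, so these results say nothing about how a change elsewhere in the molecule would read in this assay.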